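This account rests on a few compounds, and the source may have more. Where it says the series, first, only, none or still open, it means among the compounds named here.

In a functional assay on DLD-1 cells (Homo sapiens) for inhibition, read by MTT assay, with a stated time of 72 h (a higher number here means a weaker inhibitor, a lower number a stronger inhibitor), compound 1 `COc1ccc(CCCNCc2c(OC)cc(Oc3ccc(Nc4ccccc4)cc3)cc2OC)cc1` gives 4650 nM, compound 2 `COc1cc(Oc2cccc(Nc3ccccc3)c2)cc(OC)c1CN[C@H](C)c1ccccc1` gives 8570 nM and compound 3 `COc1ccc([C@@H](C)NCc2c(OC)cc(Oc3cccc(Nc4ccccc4)c3)c(OC)c2OC)cc1` gives 3500 nM. Compound 2 therefore lies within the usual scatter of compound 1, while compound 3 stands beyond the scatter from compound 2 with the lower number, making it the stronger inhibitor of that pair.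

Compound 4 `COc1cc(Oc2cccc(Nc3ccccc3)c2)cc(OC)c1CN(C)C` keeps the core of compound 2 but carries dimethylamino in place of (1-phenylethyl)amino on a saturated chain carbon bound to an aromatic carbon. Within the data shown here, the measured compounds offer no step of this kind, so the expectation rests on compound 2 at 8570 nM and on the structural change alone. All three measured compounds keep an aromatic ring in the amine part, whereas compound 4 has none there, so a move towards a weaker inhibitor in this assay is expected, though its size is uncertain. The expected change is a 2.1-fold higher number from compound 2 to compound 4 (0.32 log units; beyond the scatter). For compound 4 the estimated value is 18000 nM, with an expected range of 7000 nM to 45000 nM.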

Compound 4, half-maximal inhibitory concentration: > 20000 nM
Compound 4: only a limit was reported; the forecaster's own chance of this, stated with the estimate: 20%; middle value at least 1.1-fold (0.04 log units) from the limit.
By their numbers in this assay, from the lowest: compounds 3, 1 and 2 (each within the scatter of the next, the first and the last beyond it). At a limit, above all of these: compound 4.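

The position on the saturated chain carbon bound to an aromatic carbon now has its first readable step: with dimethylamino in place of (1-phenylethyl)amino, the result is an at least 2.3-fold higher number from compound 2 to compound 4 (0.36 log units; beyond the scatter). In this assay compound 4 gives > 20000 nM, which is a limit and not a number. The step therefore fixes only the direction and a lower bound on the loss, which rests on a single compound at that limit: the limit of > 20000 nM in this assay, at which 1 of the 4 values shown sits.

The change removes the six-membered aromatic ring, the hydrogen-bond donor and the defined stereocentre all at once, and the compounds shown do not tell these three apart. From the compounds shown here alone, how a methylamino or a cyclohexylamino group would stand at this place remains open.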